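A few compounds are considered here, and "the series" means these few. Any claim that something is new, unique, unknown or untested is made for them only; others in the source may bear on it.

Working notes on the series, in a functional assay on MCF7 cells (Homo sapiens) for antiproliferative activity, read by MTT assay, with a stated time of 72 h; a higher number here means a weaker inhibitor, a lower number a stronger inhibitor. Compound 1 `CCCSc1nc(N/N=C/c2ccccc2Cl)c2nnn(Cc3ccccc3)c2n1` gives 13800 nM and compound 3 `CCCSc1nc(N/N=C(\C)c2ccccc2O)c2nnn(Cc3ccccc3)c2n1` gives 11000 nM. These two sit together, with a 1.3-fold lower number from compound 1 to compound 3 (0.10 log units; within the scatter). Compound 2 `CCCSc1nc(N/N=C/c2cccc(Cl)c2)c2nnn(Cc3ccccc3)c2n1` stands at > 64000 nM, which is a limit of the assay and not a number. Compound 3 is clearly separated from that limit, with an at least 5.8-fold lower number from compound 2 to compound 3 (0.76 log units; beyond the scatter).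

Next is compound 4 `CCCSc1nc(N/N=C(\C)c2ccc(Br)cc2)c2nnn(Cc3ccccc3)c2n1`, with the change 4-bromophenyl in place of 2-hydroxyphenyl on a carbon with a double bond to nitrogen. For the measured compounds named here, no 4-bromophenyl compound has been measured. The nearest guide is 3-chlorophenyl in place of 2-chlorophenyl, with an at least 4.6-fold higher number from compound 1 to compound 2 (0.66 log units; beyond the scatter), which shows that a change on this ring can cost at least a modest step. Among the three compounds, the two with a group named 2- hold measurable values, and compound 2 does not, so a loss is the more likely outcome, though a limit reading cannot be excluded.

The expected step is a 2.0-fold higher number from compound 3 to compound 4 (0.30 log units; within the scatter), a modest move to a higher number. For compound 4 the estimated value is 22000 nM, with an expected range of 5000 nM to 64000 nM.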

Compound 4, half-maximal inhibitory concentration: 13000 nM
For compound 4 the middle estimate is 1.7-fold (0.23 log units) above the measured one, within the range that was stated.
By their numbers in this assay, from the lowest: compounds 3, 4 and 1 (each within the scatter of the next). At a limit, above all of these: compound 2.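

At the carbon with a double bond to nitrogen, 4-bromophenyl in place of 2-hydroxyphenyl gives a 1.2-fold higher number from compound 3 to compound 4 (0.07 log units; within the scatter), so this exchange of groups, which leaves 0 hydrogen-bond donors and 0 hydrogen-bond acceptors in the entering group, does not move the number beyond the scatter. A measurable value is therefore not confined to groups named 2-, as a 1.1-fold lower number from compound 1 to compound 4 (0.03 log units; within the scatter) and an at least 4.9-fold lower number from compound 2 to compound 4 (0.69 log units; beyond the scatter) show. Compound 2 remains a limit of the assay and not a number: the limit of > 64000 nM in this assay, at which 1 of the 4 values shown sits.

Compound 2 and compound 4 differ both in the ring group and in the saturated chain carbon, and the compounds shown do not separate these two changes. Also open, on these data alone, is how an amine or a carboxylic acid on this ring would read in this assay.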